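The source may report more compounds than this note shows. Statements on the series, on what has been measured and on what is new or still open speak of the compounds shown alone.

Measured so far:
compound 1 `c1ccc(CN(CCCCN(C[C@H]2Cc3ccccc3CN2)[C@H]2CCCc3cccnc32)Cc2ccccn2)nc1`: in a functional assay on cells for agonist activity at C-X-C chemokine receptor type 4 (Homo sapiens), read by fluorescence and calcium flux, with a stated time of 90 s (a higher number here means that more compound is needed for the effect, a lower number that less compound is needed), compound 1 gives > 30000 nM, a limit of the assay.
compound 2 `c1cncc(CN(CCCCN(C[C@H]2Cc3ccccc3CN2)[C@H]2CCCc3cccnc32)Cc2cccnc2)c1`: in this assay compound 2 gives > 30000 nM, again a limit of the assay.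
compound 3 `c1ccc2c(c1)CN[C@@H](CN(Cc1ccc(CNC3CCOCC3)cc1)[C@H]1CCCc3cccnc31)C2`: in this assay compound 3 gives > 30000 nM, a limit of the assay.

Compound 3 therefore stands at no number at all: its value is a limit, and the two other values shown are limits as well, as recorded by the limit of > 30000 nM in this assay, at which 3 of the 3 values shown sit. For the measured compounds named here, no pair of measured compounds differs in a single place, so no measured step size exists for the series yet.

Compound 4 `c1ccc(CNCc2ccc(CN(C[C@H]3Cc4ccccc4CN3)[C@H]3CCCc4cccnc43)cc2)nc1` differs from compound 3 in one place: (pyridin-2-yl)methyl in place of oxan-4-yl on an amine nitrogen. Compound 1 and compound 2, which also carry pyridinylmethyl groups, show only limits; their values say no more than that. The step expected in this assay, a number no higher from compound 3 to compound 4 (the limit leaves the size open), is none beyond the scatter, and a limit is the most probable outcome again. Compound 4 is expected to give 30000 nM, with a range from 10000 nM to 100000 nM.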

Compound 4, half-maximal effective concentration in the C-X-C chemokine receptor type 4 assay: > 30000 nM
Compound 4 ended at the assay's limit; the forecaster's own chance of this, stated with the estimate: 75%; the middle value sits exactly at the limit.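

In the C-X-C chemokine receptor type 4 assay compound 3 gives > 30000 nM, a limit of the assay.

In the C-X-C chemokine receptor type 4 assay compound 4 gives > 30000 nM, also a limit of the assay.

In the C-X-C chemokine receptor type 4 assay no step can be read from compound 3 to compound 4, as each compound sits at a limit of the assay: the limit of > 30000 nM in the C-X-C chemokine receptor type 4 assay, at which 4 of the 4 values shown sit.

In a physicochemical assay for permeability, using PAMPA, with a stated time of 4 h, at pH 5.5, tested at 100 uM (on this read-out higher numbers stand for higher permeability and lower numbers for lower permeability), compound 3 has the entry "not determined" (no result reported). In the physicochemical assay compound 4 gives 16 nm/s. With no result reported for compound 3, these two compounds cannot be compared on this read-out.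

The compounds shown leave open which structural change, if any, would give a readable number in the C-X-C chemokine receptor type 4 assay.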